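Sulfonyl for benzyl on the piperazine: a predicted step

The source may hold more compounds than are shown below. What is called first, only, known or untested is meant among the compounds shown, and "the series" means these compounds.

Compound 1 `COC(=O)c1ccc(C2SCC(=O)N2c2ccc(N3CCN(Cc4cc(OC)c(OC)c(OC)c4)CC3)cn2)c(OC)c1`: 41000 nM
Compound 2 `COC(=O)c1ccc(C2SCC(=O)N2c2ccc(N3CCN(Cc4ccc(Cl)c(Cl)c4)CC3)cn2)c(OC)c1`: 61000 nM
Compound 3 `COC(=O)c1ccc(C2SCC(=O)N2c2ccc(N3CCN(S(=O)(=O)c4cc(Cl)ccc4Cl)CC3)cn2)c(OC)c1`: > 100000 nM (a limit)

In a functional assay on Jurkat cells (Homo sapiens) for antiproliferative activity, read by MTT assay and trypan blue exclusion, with a stated time of 72 h (a higher number here means a weaker inhibitor, a lower number a stronger inhibitor), compound 2 gives the highest of the two numbers, with compound 1 nearest, and the step of a 1.5-fold higher number from compound 1 to compound 2 (0.17 log units; within the scatter) lies within the scatter. For compound 3 the value is only a limit of the assay, described by the limit of > 100000 nM in this assay, at which 1 of the 3 values shown sits; the step of an at least 1.6-fold higher number from compound 2 to compound 3 (0.21 log units; that floor lies within the scatter) therefore has a floor that lies within the scatter.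

Compound 4 `COC(=O)c1ccc(C2SCC(=O)N2c2ccc(N3CCN(S(=O)(=O)c4ccc(OC)cc4)CC3)cn2)c(OC)c1` differs from compound 2 by (4-methoxyphenyl)sulfonyl in place of 3,4-dichlorobenzyl on an amine nitrogen in a ring. For the measured compounds named here, the one measured step of the same kind, an at least 1.6-fold higher number from compound 2 to compound 3 (0.21 log units; that floor lies within the scatter), points to a higher number or to no change beyond the scatter. Compound 4 is therefore expected to give 85000 nM, between 40000 nM and 200000 nM, meaning an expected 1.4-fold higher number from compound 2 to compound 4 (0.14 log units; within the scatter).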

Compound 4, half-maximal inhibitory concentration: 45200 nM
Estimate against measurement, compound 4: 1.9-fold (0.27 log units) above, and the stated range covers the measured number.
By their numbers in this assay, from the lowest: compounds 1, 4 and 2 (each within the scatter of the next). At a limit, above all of these: compound 3.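

In this assay, a sulfonyl link on the ring nitrogen still gives a measurable value, as (4-methoxyphenyl)sulfonyl in place of 3,4-dichlorobenzyl gives a 1.3-fold lower number from compound 2 to compound 4 (0.13 log units; within the scatter). The group on the sulfonyl sulfur makes a difference, with 4-methoxyphenyl in place of 2,5-dichlorophenyl giving an at least 2.2-fold lower number from compound 3 to compound 4 (0.34 log units; beyond the scatter). That step rests on compound 3, whose value is a limit: the limit of > 100000 nM in this assay, at which 1 of the 4 values shown sits.

The compounds shown leave open whether the methoxy group or the absence of the two chlorines drives this step. They also leave open how an amine or a carboxylic acid on that phenyl ring would compare.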